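Chloro added to the anilino ring of a thiosemicarbazone

The source may hold more compounds than are shown below. What is called first, only, known or untested is meant among the compounds shown, and "the series" means these compounds.

Measured compounds:
compound 1 `Cc1ccc(Oc2ccc(/C=N/NC(=S)Nc3ccccc3)cc2)cc1` 5.39
compound 2 `S=C(N/N=C/c1ccc(Oc2ccc(Cl)cc2)cc1)Nc1ccccc1` 5.52
compound 3 `Fc1ccc(Oc2ccc(/C=N/NC(=S)Nc3ccc(Br)cc3)cc2)cc1` 5.82

In a physicochemical assay for lipophilicity, in phosphate buffer, measured as octanol-water partition, with a stated time of 24 h (a higher number here means a more lipophilic compound, a lower number a more polar compound), compound 1 gives 5.39, the lowest of the three numbers; compound 2 sits within the scatter of it, while compound 3 lies beyond the scatter above it. Among the measured compounds shown here, the one measured step, a number 0.13 log units higher from compound 1 to compound 2 (within the scatter), concerns a different exchange and falls within the scatter, so it bears only loosely on the present case. Compound 4 `Cc1ccc(Oc2ccc(/C=N/NC(=S)Nc3ccc(Cl)cc3)cc2)cc1` differs from compound 1 by chloro in place of hydrogen on an aromatic carbon. For the measured compounds named here, no measured pair shows this particular exchange. Compound 3, which carries two halogens on its outer rings, gives the highest value among the measured compounds, and that is the only hint available. Compound 4 is therefore expected to come out higher than compound 1 in this assay, with a number 0.51 log units higher from compound 1 to compound 4 (beyond the scatter) as the estimated step. The estimate for compound 4 is 5.9, with a range from 5.5 to 6.3.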

Compound 4, partition coefficient: 5.97
Compound 4: middle estimate off by 0.07 log units, on the low side; measured number inside the range.
By their numbers in this assay, from the lowest: compounds 1, 2, 3 and 4 (each within the scatter of the next, the first and the last beyond it).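

In this assay, the change from anilino to (4-chlorophenyl)amino on the core of compound 1 gives a number 0.58 log units higher from compound 1 to compound 4 (beyond the scatter), so a single chloro in this place, on the ring carbon para to a large group, moves the read-out beyond the scatter. Among the compounds shown here, the only earlier step, a number 0.13 log units higher from compound 1 to compound 2 (within the scatter), was a different exchange at a different place and stayed within the scatter, so it could not show this. Nothing measured here accounts for the size of the new step.

The compounds shown leave open how a methoxy group, an amine or a carboxylic acid would read in this same place. They also leave open whether chloro in place of hydrogen here gives a similar step on the core of compound 2.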